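A longer chain on the shared core

The source may report more compounds than this note shows. Statements on the series, on what has been measured and on what is new or still open speak of the compounds shown alone.

Compound 1 `C#CCNCc1cn(-c2cc(NC(=S)NCC)ncn2)cn1`: 2.78 10^-6 cm/s
Compound 2 `C#CCN(C)Cc1cn(-c2cc(NC(=S)NCC)ncn2)cn1`: 3.16 10^-6 cm/s
Compound 3 `C#CCNCCCc1cn(-c2cc(NC(=S)NCC)ncn2)cn1`: not yet measured

In an ADME assay for permeability, using PAMPA, in phosphate buffer, with a stated time of 12 h, tested at 100 ug/mL (a lower number here means that the compound crosses the layer more slowly, a higher number that the compound crosses the layer faster), compound 2 gives 3.16 10^-6 cm/s, within the scatter of compound 1. Compound 3 carries 2-(propargylamino)ethyl in place of methyl(propargyl)amino on a saturated chain carbon bound to an aromatic carbon. Among the compounds with values here, the one measured step, a 1.1-fold higher number from compound 1 to compound 2 (0.06 log units; within the scatter), is methyl in place of hydrogen on an amine nitrogen. Within the data shown here, it is small, and no measured step covers this change of chain, so no clear direction can be expected. The estimated step, a 1.1-fold lower number from compound 2 to compound 3 (0.02 log units; within the scatter), stays within the scatter. The estimate for compound 3 is 3 10^-6 cm/s, with an expected range of 1.5 10^-6 cm/s to 6 10^-6 cm/s.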

Compound 3, apparent permeability: 3.26 10^-6 cm/s
For compound 3 the middle estimate is 1.1-fold (0.04 log units) below the measured one, within the range that was stated.
By their numbers in this assay, from the lowest: compounds 1, 2 and 3 (each within the scatter of the next).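

In this assay, 2-(propargylamino)ethyl in place of methyl(propargyl)amino gives a 1.0-fold higher number from compound 2 to compound 3 (0.01 log units; within the scatter), and the same group in place of propargylamino gives a 1.2-fold higher number from compound 1 to compound 3 (0.07 log units; within the scatter). On this saturated chain carbon, then, a longer chain that also carries a hydrogen-bond donor, absent from methyl(propargyl)amino, leaves the read-out within the scatter of both earlier compounds. No measurement at hand offers an explanation for this result. The compounds shown leave open whether a chain ending in a carboxylic acid, or a piperidine ring, would also stay within the scatter here.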